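Nitro for methyl on the thiazole of compound 1

The compounds below may be only part of what the source reports. "The series", "measured", "known", "first", "only" and "open" are said of these compounds alone.

Within the data shown here, compound 1 (`Cc1cnc(NC(=O)COc2ccc(/C=C3\SC(=O)NC3=O)cc2)s1`) is the only member of this small set with a full number. In a functional assay on K562 cells (Homo sapiens) for cytotoxicity, read by sulforhodamine B assay, with a stated time of 48 h (a lower number here means a stronger inhibitor of growth, a higher number a weaker inhibitor of growth), compound 1 gives 2240 nM, the one concentration given here as a full number. Compound 2 (`CCCCC1=NC2(CCCC2)C(=O)N1C(=O)COc1ccc(/C=C2/SC(=O)NC2=O)cc1`) is reported in this assay only as < 100000 nM, a limit of the assay and not a measured concentration, matching (the limit of < 100000 nM in this assay, at which 1 of the 2 values shown sits). Among the measured compounds shown here, because no two measured compounds differ in a single place, no measured step exists to calibrate the change to compound 3 (`O=C(COc1ccc(/C=C2\SC(=O)NC2=O)cc1)Nc1ncc([N+](=O)[O-])s1`), which differs from compound 1 by nitro in place of methyl on an aromatic carbon. With nothing in the set to anchor the direction, the step from compound 1 to compound 3 in this assay is expected to be small, within or only slightly beyond the usual scatter, as a 1.4-fold lower number from compound 1 to compound 3 (0.15 log units; within the scatter). Compound 3 is therefore estimated at 1600 nM in this assay, with a plausible range from 400 nM to 6500 nM.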

Compound 3, concentration for 50% growth inhibition: < 100000 nM
Compound 3 ended at the assay's limit (the forecaster's own chance of this, stated with the estimate: 10%); the middle value does not contradict the limit.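

In this assay, among these compounds, compound 3 gives < 100000 nM which is a limit of the assay and not a number, so no step from compound 1 to compound 3 can be read. The compounds shown leave open whether nitro in place of methyl on an aromatic carbon changes growth inhibition at all, and in which direction: the limit of < 100000 nM in this assay, at which 2 of the 3 values shown sit.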